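The source may report more compounds than this note shows. Statements on the series, on what has been measured and on what is new or still open speak of the compounds shown alone.

In a functional assay on PC-3 cells (Homo sapiens) for inhibition, read by MTT assay (a higher number here means a weaker inhibitor, a lower number a stronger inhibitor), compound 1 `O=C(CCCCCCC(=O)Nc1nnc(-c2ccco2)s1)NO` gives 880 nM, and compound 2 `Cc1ccc(-c2nnc(NC(=O)CCCCCCC(=O)NO)s2)o1` gives 880 nM. Among the measured compounds shown here, these two share the lowest number among the three compounds measured so far. Compound 3 `CC(C)c1ccc(C(C)c2nnc(NC(=O)CCC(=O)NO)s2)cc1` gives 14700 nM, a much higher number, but it differs from compound 2 in more than one place, so it offers little guidance on a single swap.

The next compound to consider is compound 4 `O=C(CCCCCCC(=O)Nc1nnc(-c2cccs2)s1)NO`, which differs from compound 2 by one exchange on an aromatic carbon of the shared core: thiophen-2-yl in place of 5-methylfuran-2-yl on an aromatic carbon. For the measured compounds named here, only one measured step touches the group that leaves. That step is no change at the digits printed from compound 1 to compound 2 (within the scatter), and it involved methyl in place of hydrogen on an aromatic carbon. Going by the values given here, it shows that removing the methyl from the furan group left the number in place, but it says nothing directly about thiophen-2-yl, which no measured compound carries. With so little evidence, no shift in either direction can be argued, so the working expectation is no change beyond the scatter. The expected result is a 1.1-fold lower number from compound 2 to compound 4 (0.04 log units; within the scatter), a step estimated to be small. For compound 4 the estimated value is 800 nM, with an expected range from 300 nM to 2200 nM.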

Compound 4, half-maximal inhibitory concentration: 880 nM
For compound 4 the middle estimate is 1.1-fold (0.04 log units) below the measured one, and the stated range covers the measured number.
By their numbers in this assay, from the lowest: compounds 1, 2 and 4 (each within the scatter of the next); then compound 3.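

In this assay, among the compounds shown here, the earlier compounds varied only a methyl on the furan, whereas here the five-membered aromatic ring itself is exchanged: thiophen-2-yl in place of 5-methylfuran-2-yl gives no change at the digits printed from compound 2 to compound 4 (within the scatter) and thiophen-2-yl in place of furan-2-yl gives no change at the digits printed from compound 1 to compound 4 (within the scatter). This shows that at this place, on an aromatic carbon next to the ring nitrogen and next to the ring sulfur, a ring carrying sulfur and a ring carrying oxygen stand level, with or without the methyl on the furan, so the choice among these three groups does not separate compounds 1, 2 and 4 in this assay. No measurement shown here offers any explanation for this level result.

As far as these compounds go, all three groups are five-membered aromatic rings with one hetero atom, so it remains open whether a six-membered ring such as phenyl or pyridyl, or a simple amine, would keep the number level at this place. From the compounds shown here alone, it also remains open whether a methyl on the thiophene would behave as the methyl on the furan does.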